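This account rests on a few compounds, and the source may have more. Where it says the series, first, only, none or still open, it means among the compounds named here.

Of the compounds shown here, three with a shared core have been measured in a functional assay on a cell-free system (plasma) for inhibition of thromboxane A2 receptor (Homo sapiens); on this read-out higher numbers stand for weaker inhibition and lower numbers for stronger inhibition. Compound 1 `CSCSCC1C2CCC(O2)C1C/C=C\CCCC(=O)O` gives 700 nM. Compound 2 `CCCCSCSCC1C2CCC(O2)C1C/C=C\CCCC(=O)O` gives 700 nM. Compound 3 `CCCCSCC1C2CCC(O2)C1C/C=C\CCCC(=O)O` gives 1000 nM. Compound 4 `CCCCCCCSCC1C2CCC(O2)C1C/C=C\CCCC(=O)O` has not yet been measured.

The change from compound 1 to compound 2 is propyl in place of hydrogen on a saturated chain carbon bound to a sulfur. Its effect was no change at the digits printed from compound 1 to compound 2 (within the scatter). The same structural change, occurring twice among these compounds, also takes compound 3 to compound 4: propyl in place of hydrogen on a saturated chain carbon, four bonds along the chain from a sulfur. The two cores differ by propyl in place of methylsulfanyl on a saturated chain carbon bound to a sulfur. The surroundings of the change are not identical: in compound 1 the place is on a saturated chain carbon bound to a sulfur, whereas in compound 3 it is on a saturated chain carbon, four bonds along the chain from a sulfur, so the two changes are the same kind of change rather than the same change.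

Because the earlier step was no change at the digits printed from compound 1 to compound 2 (within the scatter), a similar step, no change at the digits printed from compound 3 to compound 4 (within the scatter), is expected for compound 4. Compound 4 is therefore estimated at 1000 nM, with a likely range from 500 nM to 2000 nM.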

Compound 4, half-maximal inhibitory concentration: 42000 nM
Compound 4: the middle estimate sits 42-fold (1.62 log units) below what was measured; measured number above the stated range.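

In this assay, propyl in place of hydrogen on a saturated chain carbon, four bonds along the chain from a sulfur, gives a 42-fold higher number from compound 3 to compound 4 (1.62 log units; beyond the scatter). Adding propyl did not carry over from one core to the other in this assay: the same change on two cores in this assay, no change at the digits printed (within the scatter) from compound 1 to compound 2 and a 42-fold higher number (1.62 log units; beyond the scatter) from compound 3 to compound 4, 42-fold (1.62 log units) apart, beyond the scatter of two such steps. Compound 4 also stands far from the two compounds with a further sulfur in the side chain: hexyl in place of butylsulfanyl gives a 60-fold higher number from compound 2 to compound 4 (1.78 log units; beyond the scatter), and hexyl in place of methylsulfanyl gives a 60-fold higher number from compound 1 to compound 4 (1.78 log units; beyond the scatter). Among these compounds, this shows that the effect of this change on one core cannot simply be assumed on the other, but with only one pair on each core, it does not show why the two steps differ or how general the difference is.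

The compounds shown leave open how the number moves between compound 3 and compound 4, since a pentyl or hexyl chain in the same place would show whether the rise is gradual or abrupt. They also leave open whether a longer chain containing a further sulfur, or one ending in an amine, would behave like compound 4.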